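The source may report more compounds than this note shows. Statements on the series, on what has been measured and on what is new or still open speak of the compounds shown alone.

In a functional assay (Nicotiana tabacum) (on this read-out lower numbers stand for stronger inhibition and higher numbers for weaker inhibition), compound 1 `CSc1nc(Nc2ccccc2)c2cccnc2n1` gives 15900 nM and compound 2 `CSc1nc(Nc2ccc(Br)cc2)c2cccnc2n1` gives 5750 nM while compound 3 `CCc1ccc(Nc2nc(SC)nc3ncccc23)cc1` gives 7150 nM on the same read-out. Compound 3 lies within the scatter of compound 2 and at a lower number than compound 1. Compound 4 `COc1ccc(Nc2nc(SC)nc3ncccc23)cc1` carries one change from compound 3, methoxy in place of ethyl on an aromatic carbon para to a large group (methoxy in place of ethyl on an aromatic carbon). Two steps at this place are modest, a 2.8-fold lower number from compound 1 to compound 2 (0.44 log units; beyond the scatter) and a 2.2-fold lower number from compound 1 to compound 3 (0.35 log units; beyond the scatter) with both beyond the scatter, whereas a 1.2-fold higher number from compound 2 to compound 3 (0.09 log units; within the scatter) stays within it. Within the data shown here, no methoxy compound has been measured yet, so no step beyond the scatter is expected in this assay for this exchange. Compound 4 is estimated at 7000 nM with an expected range from 3000 nM to 16000 nM on this read-out. The expected move is a 1.0-fold lower number from compound 3 to compound 4 (0.01 log units; within the scatter) and is estimated to stay small.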

Compound 4, half-maximal inhibitory concentration: 9420 nM
Compound 4: the middle estimate sits 1.3-fold (0.13 log units) below what was measured; low and high end bracket the measured number.
By their numbers in this assay, from the lowest: compounds 2, 3, 4 and 1 (each within the scatter of the next, the first and the last beyond it).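

In this assay methoxy on this aromatic carbon, para to a large group, shows a 1.3-fold higher number from compound 3 to compound 4 (0.12 log units; within the scatter), and a 1.6-fold higher number from compound 2 to compound 4 (0.21 log units; within the scatter). Unlike bromo and ethyl, methoxy shows no step beyond the scatter from the unsubstituted compound, with a 1.7-fold lower number from compound 1 to compound 4 (0.23 log units; within the scatter). The hydrogen-bond acceptor brought in by methoxy therefore gives no step beyond the scatter against ethyl.

Going by these compounds, whether an amine or a carboxylic acid at this place would move the number further remains open. No available evidence bears on the small steps seen with methoxy.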